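The source may report more compounds than this note shows. Statements on the series, on what has been measured and on what is new or still open speak of the compounds shown alone.

Compound 1 `NC1=NC2(CCSCC2)N(OCCCOc2ccc(Br)cc2)C(N)=N1`: 740 nM. Compound 2 `Cc1ccc(OCCCON2C(N)=NC(N)=NC23CCOCC3)cc1`: 1060 nM.

In a functional assay on A549 cells (Homo sapiens) for antiproliferative activity, read by MTT assay, with a stated time of 72 h (a higher number here means a weaker inhibitor, a lower number a stronger inhibitor), compound 1 gives 740 nM, the lowest of the two numbers shown. Compound 2 gives 1060 nM in this assay, and the gap between the two lies within the scatter, so neither compound can be set above the other on these figures alone.

Compound 3 `COc1ccc(OCCCON2C(N)=NC(N)=NC23CCSCC3)cc1` differs from compound 1 in a single place: methoxy in place of bromo on an aromatic carbon. Going by the values given here, no pair of measured compounds that differ in one place is available, so nothing measured shows how large a step of this kind tends to be. The expectation therefore rests on the two values shown and on the change itself, and is a modest one: the step from compound 1 is expected to be a 1.4-fold higher number from compound 1 to compound 3 (0.13 log units; within the scatter), a shift that may well not exceed the scatter. Compound 3 is accordingly estimated at 1000 nM, within a range from 400 nM to 2500 nM.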

Compound 3, half-maximal inhibitory concentration: 240 nM
The estimate for compound 3 lay 4.2-fold (0.62 log units) above the measured number; measured number below the stated range.
By their numbers in this assay, from the lowest: compound 3; then compounds 1 and 2 (each within the scatter of the next).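

In this assay, going by these compounds alone, the change from 4-bromophenyl to 4-methoxyphenyl gives a 3.1-fold lower number from compound 1 to compound 3 (0.49 log units; beyond the scatter), the first step here between compounds that differ in one place. It shows that this aromatic carbon, para to a large group, is not indifferent to what it carries, which the two earlier compounds could not show, as they differ in more than one place. No measurement at hand bears on why methoxy gives the lower number here.

From the compounds shown here alone, whether a chlorine, an amine or a carboxylic acid at the same carbon would fall nearer to methoxy or to bromo remains open. Going by these compounds, it is also open whether the same change would give a step of similar size on the core of compound 2.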